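The source may hold more compounds than are shown below. What is called first, only, known or untested is meant among the compounds shown, and "the series" means these compounds.

Measured in an ADME assay on the whole organism (Mus musculus, strain CD-1) for pharmacokinetics, read by LC-MS, in a xenograft, at a dose of 100 mg/kg by the intraperitoneal route; a higher number here means more compound in the circulation at the dose given, a lower number less compound in the circulation:
compound 1, `CC(C)(C)NS(=O)(=O)c1cccc(NC(=O)c2ncc(NS(C)(=O)=O)nc2N2CCC3(CC2)CC3)n1`, 22600 nM
compound 2, `CC(C)(C)NS(=O)(=O)c1cccc(NC(=O)c2ccc(NS(=O)(=O)C3(C)CC3)cc2N2CCC3(CC2)CC3)c1`, 26500 nM

Compound 2 gives the larger of the two numbers in this assay, yet the gap to compound 1 lies within the scatter, so the two compounds cannot be told apart on these values. The step from compound 2 to compound 3 replaces one group on a sulfonyl sulfur whose other neighbour is the sulfonamide nitrogen, and compound 3 is `CC(C)(C)NS(=O)(=O)c1cccc(NC(=O)c2ccc(NS(C)(=O)=O)cc2N2CCC3(CC2)CC3)c1`. The change reads (methyl in place of 1-methylcyclopropyl on a sulfonyl sulfur). Within the data shown here, no measured pair follows this change, so the expectation rests on the two values alone. The step from compound 2 to compound 3 is expected to be a 1.1-fold lower number from compound 2 to compound 3 (0.04 log units; within the scatter), that is, nothing beyond the scatter in either direction. Compound 3 is therefore estimated at 24000 nM in this assay, within a range from 12000 nM to 48000 nM.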

Compound 3, maximal plasma concentration: 12600 nM
Compound 3: middle estimate off by 1.9-fold (0.28 log units), on the high side; the range from low to high includes it.
By their numbers in this assay, from the lowest: compounds 3, 1 and 2 (each within the scatter of the next, the first and the last beyond it).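

In this assay, the group on a sulfonyl sulfur whose other neighbour is the sulfonamide nitrogen does affect the read-out: methyl in place of 1-methylcyclopropyl gives a 2.1-fold lower number from compound 2 to compound 3 (0.32 log units; beyond the scatter). Among these compounds, this is the only comparison so far between compounds that differ in one place, so it is the first direct reading of this position, and the step is a modest one. Nothing available accounts for the step.

The compounds shown leave open how other groups on that sulfur, such as ethyl, unsubstituted cyclopropyl or a dimethylamino group, would compare with methyl and 1-methylcyclopropyl. They also leave open whether the same change would give a step of similar size on the core of compound 1, which already carries the methylsulfonyl group.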